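The compounds below may be only part of what the source reports. "The series", "measured", "known", "first", "only" and "open" are said of these compounds alone.

In a functional assay on MKN-45 cells (Homo sapiens) for inhibition, read by CCK-8 assay, with a stated time of 24 h (a lower number here means a stronger inhibitor, a higher number a weaker inhibitor), compound 1 (`O=C1Nc2ccc(F)cc2/C1=C/c1ccc(-c2cn(-c3ccc(F)cc3)nn2)cc1`) gives > 20000 nM as a limit of the assay, not a number. Within the data shown here, compound 2 (`O=C1Nc2ccc(F)cc2/C1=C/c1ccc(-c2cn(-c3cccc(Cl)c3)nn2)cc1`) gives 14100 nM in this assay and so holds the only actual number. Among the measured compounds shown here, the one measured step is an at least 1.4-fold lower number from compound 1 to compound 2 (0.15 log units; that floor lies within the scatter) and it rests on the limit of > 20000 nM in this assay, at which 1 of the 2 values shown sits, as its starting point. Compound 3 (`N#Cc1cccc(-n2cc(-c3ccc(/C=C4\C(=O)Nc5ccc(F)cc54)cc3)nn2)c1`) brings a new change, cyano in place of chloro on an aromatic carbon with cyano in place of chloro on an aromatic carbon, meta to a large group. For the measured compounds named here, no measured compound carries cyano, so the only guide is an at least 1.4-fold lower number from compound 1 to compound 2 (0.15 log units; that floor lies within the scatter) and it gives no ground for expecting a clear shift in either direction. The expected move is a 1.1-fold higher number from compound 2 to compound 3 (0.03 log units; within the scatter) and it is not expected to go beyond the scatter in this assay in either direction. For compound 3 the estimate is 15000 nM with an expected range from 6000 nM to 30000 nM in this same read-out.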

Compound 3, half-maximal inhibitory concentration: > 20000 nM
Compound 3: no number, only a limit (the forecaster's own chance of this, stated with the estimate: 30%); middle value at least 1.3-fold (0.12 log units) away from the limit.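

The change of chloro to cyano on an aromatic carbon, meta to a large group, gives an at least 1.4-fold higher number from compound 2 to compound 3 (0.15 log units; that floor lies within the scatter). Compound 3 gives > 20000 nM, which is a limit of the assay and not a number, and the step between compound 1 and compound 3 cannot be read, as both values are limits. Cyano therefore brings no lower number than chloro at this position in this assay, and compound 2 remains the only compound with an actual number, the others sitting at one limit: the limit of > 20000 nM in this assay, at which 2 of the 3 values shown sit.

Going by these compounds, it remains open whether an amine, a methoxy group or a carboxylic acid in place of chloro at this position would give a lower number than compound 2. Also open, on these data alone, is how a 4-chlorophenyl group on the aromatic nitrogen would compare with the 3-chlorophenyl group of compound 2.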